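Compound 3 to compound 4: phenethyl on the sulfur

A few compounds are considered here, and "the series" means these few. Any claim that something is new, unique, unknown or untested is made for them only; others in the source may bear on it.

Measured in a functional assay on SMMC-7721 cells (Homo sapiens) for inhibition, read by CCK-8 assay, with a stated time of 72 h, tested at 2 uM; on this read-out higher numbers stand for more inhibition of growth at the one concentration tested and lower numbers for less inhibition of growth:
compound 1 `Cc1cc(C)cc(SCc2ccc(/C=C/C(=O)Nc3ccccc3N)cc2)c1`: 8.61%
compound 2 `Nc1ccccc1NC(=O)/C=C/c1ccc(CSc2ccc(Cl)cc2)cc1`: 15.2%
compound 3 `Nc1ccccc1NC(=O)/C=C/c1ccc(CSc2ccc(F)cc2)cc1`: 18.3%

Compound 3 gives 18.3%, but it cannot be separated from the other two compounds. The measured values show a number 9.7 percentage points higher from compound 1 to compound 3 (within the scatter) and a number 3.1 percentage points higher from compound 2 to compound 3 (within the scatter). The third comparison shows a number 6.6 percentage points higher from compound 1 to compound 2 (within the scatter).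

Compound 4 `Nc1ccccc1NC(=O)/C=C/c1ccc(CSCCc2ccccc2)cc1` has not yet been measured. It carries phenethyl in place of 4-fluorophenyl on a sulfur. The three measured steps bear on this change only loosely. Each swaps one substituted phenyl group on the sulfur for another, and none brings in phenethyl. They do show that changes at this place have so far stayed small, so no step beyond the scatter is expected, and the data favour no direction. The estimated change is a number 4.3 percentage points lower from compound 3 to compound 4 (within the scatter), though the untested group leaves this uncertain. For compound 4 the expected value is 14%, with an estimated range from 3% to 30%.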

Compound 4, percent growth inhibition at one concentration: 14.7%
Beside the measured number, compound 4's estimate is 0.7 percentage points below it, within the range that was stated.
By their numbers in this assay, from the lowest: compounds 1, 4, 2 and 3 (each within the scatter of the next).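

In this assay, the change to phenethyl gives a number 3.6 percentage points lower from compound 3 to compound 4 (within the scatter) and a number 0.5 percentage points lower from compound 2 to compound 4 (within the scatter) and a number 6.1 percentage points higher from compound 1 to compound 4 (within the scatter) as its three steps. Within the data shown here, until now, only substituted phenyl groups had stood on the sulfur, and these steps extend the earlier picture to phenethyl, a group of a different kind: all four compounds remain within the scatter of one another, and no step separates them. Nothing available gives a reason for this result.

On these data alone, it remains open whether any group on the sulfur can move the number beyond the scatter, for example a longer chain or phenethyl bearing an amine or a carboxylic acid. The single concentration also leaves open how these compounds would compare at other concentrations.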